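This account rests on a few compounds, and the source may have more. Where it says the series, first, only, none or still open, it means among the compounds named here.

In a physicochemical assay for solubility (a lower number here means a less soluble compound, a higher number a more soluble compound), compound 1 `CNC(=O)c1cc(C(=O)NC2CC2)cn(Cc2cccc(F)c2)c1=O` gives >= 133 ug/mL, which is a limit of the assay and not a number. Within the data shown here, compound 2 `CNC(=O)c1cc(C(=O)NC2CC2)cn(Cc2cccc(OC)c2)c1=O` gives 79 ug/mL, the only actual number available so far in this small series. The next compound, compound 3 `CNC(=O)c1cc(C(=O)NC2CC2)cn(Cc2ccc3nc[nH]c3c2)c1=O`, carries 1H-benzimidazol-6-yl in place of 3-methoxyphenyl on a saturated chain carbon bound to an aromatic nitrogen. Among the measured compounds shown here, only one measured step offers any guidance: methoxy in place of fluoro on an aromatic carbon, which is an at least 1.6-fold lower number from compound 1 to compound 2 (0.22 log units; that floor lies within the scatter). That step exchanged a single group on an aromatic carbon, whereas the new change replaces the whole 3-methoxyphenyl, so it bears on compound 3 only loosely. With compound 2 at 79 ug/mL as the sole anchor, no step beyond the scatter is expected in this assay, and neither direction can be favoured. The estimated change is a 1.1-fold higher number from compound 2 to compound 3 (0.03 log units; within the scatter). For compound 3 the expected value is 85 ug/mL, with an estimated range from 30 ug/mL to 200 ug/mL.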

Compound 3, solubility: >= 163 ug/mL
Compound 3 gave a limit, no number; the forecaster's own chance of this, stated with the estimate: 15%; at least 1.9-fold (0.28 log units) between middle value and limit.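

In this assay, 1H-benzimidazol-6-yl in place of 3-methoxyphenyl on a saturated chain carbon bound to an aromatic nitrogen gives an at least 2.0-fold higher number from compound 2 to compound 3 (0.31 log units; beyond the scatter), and this is the only readable step among the compounds shown that is printed as beyond the scatter. The earlier step exchanged a single group on an aromatic carbon and its floor stayed within the scatter, whereas this one shows that replacing the whole group at this place can move the read-out measurably. Compound 3 gives a limit of the assay and not a number, so the step sets only a floor and its full size stays unknown: the limit of >= 163 ug/mL in this assay, at which 1 of the 3 values shown sits.

The step between compound 1 and compound 3 cannot be read, since both values are limits, so the 1H-benzimidazol-6-yl group cannot be ranked against 3-fluorophenyl. On these data alone, it also remains open whether the step needs the whole 1H-benzimidazol-6-yl group, or whether a smaller group at the same place, such as pyridin-3-yl or an aminophenyl, would give a similar read-out.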